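Replacing acetyl with 4-methoxyphenyl on the ring nitrogen

The source may hold more compounds than are shown below. What is called first, only, known or untested is meant among the compounds shown, and "the series" means these compounds.

Compound 1 `CC(C)N1CCN(c2nc(Nc3ccc(C#N)c(C(F)(F)F)c3)nc(Oc3ccnc4ccccc34)n2)CC1` gives > 100000 nM in a functional assay on DU-145 cells (Homo sapiens) for cytotoxicity, read by sulforhodamine B assay, with a stated time of 48 h; a higher number here means a weaker inhibitor of growth, a lower number a stronger inhibitor of growth.
Compound 2 `N#Cc1ccc(Nc2nc(Oc3ccnc4ccccc34)nc(N3CCN(c4ccccn4)CC3)n2)cc1C(F)(F)F` gives > 100000 nM in this assay.
Compound 3 `CC(=O)N1CCN(c2nc(Nc3ccc(C#N)c(C(F)(F)F)c3)nc(Oc3ccnc4ccccc34)n2)CC1` gives > 100000 nM in this assay.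

For compound 3 this value is a limit of the assay, not a measured number. The same holds for the other two compounds, so that all three values sit together at one limit (the limit of > 100000 nM in this assay, at which 3 of the 3 values shown sit). The steps a step that the two limits leave unreadable from compound 1 to compound 2, a step that the two limits leave unreadable from compound 1 to compound 3 and a step that the two limits leave unreadable from compound 2 to compound 3 cannot be read. Each compares one limit with another, and none shows whether changing the group on the ring nitrogen moved growth inhibition at all.

Compound 4 `COc1ccc(N2CCN(c3nc(Nc4ccc(C#N)c(C(F)(F)F)c4)nc(Oc4ccnc5ccccc45)n3)CC2)cc1` differs from compound 3 by 4-methoxyphenyl in place of acetyl on an amine nitrogen in a ring. The three measured steps are the only ones that touch this position, and all are unreadable, so no direction can be drawn from them. The expectation for the step of a number no higher from compound 3 to compound 4 (the limit leaves the size open) is therefore one of no readable change, with compound 4 most likely also reported at the limit. Compound 4 is estimated at 100000 nM, within 30000 nM to 300000 nM.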

Compound 4, concentration for total growth inhibition: > 100000 nM
Compound 4: no number, only a limit (the forecaster's own chance of this, stated with the estimate: 80%); the middle value lies on the limit itself.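

In this assay compound 4 gives > 100000 nM, which is a limit of the assay and not a number. Its steps from compound 1, compound 2 and compound 3 therefore cannot be read: the limit of > 100000 nM in this assay, at which 4 of the 4 values shown sit.

The compounds shown leave open whether any group on this ring nitrogen changes growth inhibition at all.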